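A few compounds are considered here, and "the series" means these few. Any claim that something is new, unique, unknown or untested is made for them only; others in the source may bear on it.

Working notes on the series. Compound 1 `CCCCCC(=O)Nc1ccc2[nH]cc(C3CCN(C)CC3)c2n1` gives 13 nM in an assay for binding affinity to 5-hydroxytryptamine receptor 1F (Homo sapiens), read by radioligand binding; a lower number here means a stronger inhibitor, a higher number a weaker inhibitor. Compound 2 `CN1CCC(c2c[nH]c3ccc(NC(=O)c4ccc(C#N)cc4)nc23)CC1` gives 7.2 nM in this assay, and compound 3 `CN1CCC(c2c[nH]c3ccc(NC(=O)c4ccncc4)nc23)CC1` gives 8.4 nM. On the numbers shown, compound 3 sits between those of compound 2 and compound 1, and all three lie within the scatter of one another. The steps are a 1.8-fold lower number from compound 1 to compound 2 (0.26 log units; within the scatter), a 1.5-fold lower number from compound 1 to compound 3 (0.19 log units; within the scatter) and a 1.2-fold higher number from compound 2 to compound 3 (0.07 log units; within the scatter).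

Compound 4 `CCCC(=O)Nc1ccc2[nH]cc(C3CCN(C)CC3)c2n1` has not yet been measured. Its change from compound 3 is propyl in place of pyridin-4-yl on a carbonyl carbon. The measured step that bears on this is a 1.5-fold lower number from compound 1 to compound 3 (0.19 log units; within the scatter), the exchange of a chain on the carbonyl carbon for this aromatic ring, which stayed within the scatter in the one direction seen. Within the data shown here, no measured pair shows a chain as short as propyl, so the length itself is untested. In this assay the expectation is therefore a step of about a 1.4-fold higher number from compound 3 to compound 4 (0.15 log units; within the scatter), not beyond the scatter. Compound 4 is estimated at 12 nM, between 5 nM and 30 nM.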

Compound 4, inhibition constant: 6.9 nM
The estimate for compound 4 lay 1.7-fold (0.24 log units) above the measured number; low and high end bracket the measured number.
By their numbers in this assay, from the lowest: compounds 4, 2, 3 and 1 (each within the scatter of the next).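

In this assay the position on the carbonyl carbon now has a short chain measured against both aromatic groups, and neither exchange leaves the scatter (a 1.2-fold lower number from compound 3 to compound 4 (0.09 log units; within the scatter); a 1.0-fold lower number from compound 2 to compound 4 (0.02 log units; within the scatter)), so among these compounds neither a ring nor the hydrogen-bond acceptor of pyridin-4-yl is required here. Among these compounds, the first comparison of chain length, with hydrogen in place of ethyl on the saturated chain, also stays within the scatter (a 1.9-fold lower number from compound 1 to compound 4 (0.28 log units; within the scatter)), so propyl and pentyl are not told apart. Nothing available accounts for this flat response.

Going by these compounds, whether an amine or a carboxylic acid on the chain would move the number remains open. So does the effect of a chain longer than pentyl, or of a methyl group in place of the amide hydrogen.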